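Removing one methyl from the saturated ring of compound 1

This account rests on a few compounds, and the source may have more. Where it says the series, first, only, none or still open, it means among the compounds named here.

Measured compounds:
compound 1 `CC1(C)Oc2ccc(NCc3ccc(Cl)c(Cl)c3)cc2N(CCNC(=O)CO)C1=O` — 12 nM
compound 2 `Cc1nc2ccc(NCc3cccc(C(F)(F)F)c3)cc2n(CCNC(=O)C(O)CO)c1=O` — 268 nM

In an assay for inhibition of acyl-CoA desaturase 1 (Rattus norvegicus), using microsomes (a lower number here means a stronger inhibitor, a higher number a weaker inhibitor), compound 1 gives 12 nM. Compound 2, whose structure is `Cc1nc2ccc(NCc3cccc(C(F)(F)F)c3)cc2n(CCNC(=O)C(O)CO)c1=O`, gives 268 nM in this assay. Compound 1 thus stands at the lowest of the two numbers, and the gap to compound 2 is well beyond the scatter, so compound 1 counts as the stronger inhibitor of the two. Within the data shown here, these two compounds differ in several places at once, so no single-point step links them.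

Compound 3 `CC1Oc2ccc(NCc3ccc(Cl)c(Cl)c3)cc2N(CCNC(=O)CO)C1=O` has not yet been measured. It differs from compound 1 in one place: hydrogen in place of methyl on a saturated ring carbon — hydrogen in place of methyl on a saturated ring carbon. Among the measured compounds shown here, no step between measured compounds matches this change, so there is nothing here to show how the number will move.

Given that the change is small, compound 3 is expected to stay close to compound 1, with a step of a 1.7-fold higher number from compound 1 to compound 3 (0.22 log units; within the scatter) that may well sit within the scatter. The expected value for compound 3 in this assay is 20 nM, with a range from 6 nM to 70 nM.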

Compound 3, half-maximal inhibitory concentration: 80 nM
Compound 3: middle estimate off by 4.0-fold (0.60 log units), on the low side, outside the stated range (above it).
By their numbers in this assay, from the lowest: compound 1; then compound 3; then compound 2.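

Taking away one of the two methyl groups from the saturated ring carbon next to the ring oxygen produces a 6.7-fold higher number from compound 1 to compound 3 (0.82 log units; beyond the scatter) in this assay. Among these compounds, the earlier pair differed in several places at once, so this is the first single-place comparison, and it shows that this ring carbon is not a neutral spot: losing just one carbon atom, with no ring, hydrogen-bond donor, hydrogen-bond acceptor or charge changing, moves the number beyond the usual scatter, and the form with two methyl groups is the stronger inhibitor. The available data offer no measurement that explains why this single methyl group matters.

A single step cannot show how the number would move with two hydrogens on this carbon, or with a larger group such as ethyl in place of the methyl removed here. From the compounds shown here alone, it also remains open whether a step of this size would recur if the 2-(((hydroxymethyl)carbonyl)amino)ethyl group on the ring nitrogen gave way to another chain, such as one ending in a carboxylic acid.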